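Replacing the thiophene of compound 3 with 4-fluorophenyl

The compounds below may be only part of what the source reports. "The series", "measured", "known", "first", "only" and "open" are said of these compounds alone.

Measured in a functional assay on CCRF-CEM cells (Homo sapiens) for inhibition; on this read-out higher numbers stand for weaker inhibition and lower numbers for stronger inhibition:
Compound 1 `OC[C@H]1OC(n2cnc3c(-c4ccc(Cl)cc4)ncnc32)[C@H](O)[C@@H]1O` gives 900 nM
Compound 2 `OC[C@H]1OC(n2cnc3c(-c4ccco4)ncnc32)[C@H](O)[C@@H]1O` gives 600 nM
Compound 3 `Cc1ccsc1-c1ncnc2c1ncn2C1O[C@H](CO)[C@@H](O)[C@H]1O` gives 2500 nM

Compound 3 stands highest of the three at 2500 nM, which makes it the weakest inhibitor in this small set. Its gaps to the other two compounds both lie beyond the scatter.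

Compound 4 `OC[C@H]1OC(n2cnc3c(-c4ccc(F)cc4)ncnc32)[C@H](O)[C@@H]1O` has not yet been measured. It differs from compound 3 in a single place: 4-fluorophenyl in place of 3-methylthiophen-2-yl on an aromatic carbon. The change is 4-fluorophenyl in place of 3-methylthiophen-2-yl on an aromatic carbon.

Going by the values given here, no measured compound carries 4-fluorophenyl, and compound 1, with 4-chlorophenyl, is its nearest measured relative. The most relevant evidence is therefore a 2.8-fold higher number from compound 1 to compound 3 (0.44 log units; beyond the scatter), a modest step that brings in the same 3-methylthiophen-2-yl group that leaves here. Read in reverse, it points to a lower number for compound 4. The step of a 4.2-fold higher number from compound 2 to compound 3 (0.62 log units; beyond the scatter) points the same way. The step of a 1.5-fold lower number from compound 1 to compound 2 (0.18 log units; within the scatter) shows that the two other aromatic groups measured so far remain within the scatter of each other.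

The expected change is a 2.8-fold lower number from compound 3 to compound 4 (0.44 log units; beyond the scatter), a modest estimated move toward stronger inhibition. For compound 4 the estimated value is 900 nM, with an expected range from 350 nM to 2200 nM.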

Compound 4, half-maximal inhibitory concentration: 700 nM
Compound 4: middle estimate off by 1.3-fold (0.11 log units), on the high side, and the stated range covers the measured number.
By their numbers in this assay, from the lowest: compounds 2, 4 and 1 (each within the scatter of the next); then compound 3.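

In this assay, going by these compounds alone, placing 4-fluorophenyl on this aromatic carbon in place of 3-methylthiophen-2-yl gives a clear step (a 3.6-fold lower number from compound 3 to compound 4 (0.55 log units; beyond the scatter)), so a third aromatic group now stands apart from compound 3, which until now had only two such comparisons. Compound 4 shows no separation from the furan-2-yl group of compound 2 (a 1.2-fold higher number from compound 2 to compound 4 (0.07 log units; within the scatter)) or from its chloro counterpart, compound 1 (a 1.3-fold lower number from compound 1 to compound 4 (0.11 log units; within the scatter)), so fluoro and chloro cannot be told apart here, and five- and six-membered aromatic rings both appear among the three compounds that lie within the scatter of one another. No evidence is available to explain why compound 3 stands apart from these three.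

The compounds shown leave open whether that gap goes with the methyl group or with the thiophene ring itself, a question that unsubstituted thiophen-2-yl at this position would help to separate. They also leave open how this assay would respond to an amine or a carboxylic acid on this aromatic carbon.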